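The compounds below may be only part of what the source reports. "The series", "measured", "known", "first", "only" and "open" are said of these compounds alone.

Compound 2 `Cc1ccc(-c2cn(C[C@H]3c4c(ccc(O)c4C)[C@@H]4CC[C@@]5(C)C[C@]43CC5=O)nn2)cc1` and compound 1 `Cc1ccc(S(=O)(=O)Oc2ccc3c(c2C)[C@H](Cn2cc(-c4ccccn4)nn2)[C@@]24CC(=O)[C@@](C)(CC[C@@H]32)C4)cc1` share a core and differ in the group on the triazole and in the substituent on the phenolic oxygen. In a functional assay on MCF7 cells (Homo sapiens) for cytotoxicity, read by MTT assay, with a stated time of 4 days (a lower number here means a stronger inhibitor, a higher number a weaker inhibitor), compound 2 gives > 20000 nM, which is a limit of the assay rather than a number. In this assay compound 1 gives > 20000 nM, likewise a limit and not a number. Going by the values given here, compound 2 thus stands at the edge of what this assay resolves, and the same is true of compound 1, so that the limit of > 20000 nM in this assay, at which 2 of the 2 values shown sit, is the only thing the measured values show. Compound 3 `Cc1ccc(-c2cn(C[C@H]3c4c(ccc(OS(=O)(=O)c5ccc(C)cc5)c4C)[C@@H]4CC[C@@]5(C)C[C@]43CC5=O)nn2)cc1` is not yet measured; it differs from compound 2 by (4-methylphenyl)sulfonyl in place of hydrogen on an oxygen on an aromatic ring. Among the compounds with values here, no step between measured compounds is available, and the estimate can rest only on the fact that both compound 1 and compound 2 sit at the limit. The step from compound 2 to compound 3 is expected to be essentially none beyond the scatter, a step that the limit leaves unreadable from compound 2 to compound 3. Compound 3 is therefore expected to give about 30000 nM in this assay, most likely reported again only as a limit, with a range from 8000 nM to 100000 nM.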

Compound 3, half-maximal inhibitory concentration: > 20000 nM
Compound 3: no number, only a limit; the forecaster's own chance of this, stated with the estimate: 85%; the middle value is on the limit's open side.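

No step from compound 2 to compound 3, or from compound 1 to compound 3, can be read, since every value is a limit and not a number: the limit of > 20000 nM in this assay, at which 3 of the 3 values shown sit.

The compounds shown leave open how strong any of them is, and whether (4-methylphenyl)sulfonyl in place of hydrogen, or 4-methylphenyl in place of pyridin-2-yl, changes anything.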